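A few compounds are considered here, and "the series" means these few. Any claim that something is new, unique, unknown or untested is made for them only; others in the source may bear on it.

Measured so far in a functional assay on DU-145 cells (Homo sapiens) for cytotoxicity, read by MTT assay, with a stated time of 24 h; a higher number here means a weaker inhibitor, a lower number a stronger inhibitor
- Compound 1 `COc1ccc(/C=C2\CN(Cc3cn(Cc4cccc(Cl)c4)nn3)C/C(=C\c3ccc(OC)cc3)C2=O)cc1` gives 15400 nM
- Compound 2 `COc1ccc(/C=C2\CN(Cc3cn(Cc4ccc(F)cc4)nn3)C/C(=C\c3ccc(OC)cc3)C2=O)cc1` gives 59400 nM
- Compound 3 `COc1ccc(/C=C2\CN(Cc3cn(Cc4ccccc4Cl)nn3)C/C(=C\c3ccc(OC)cc3)C2=O)cc1` gives 17800 nM

Compound 3 stands level with compound 1, as a 1.2-fold higher number from compound 1 to compound 3 (0.06 log units; within the scatter) shows, and apart from compound 2, as a 3.3-fold lower number from compound 2 to compound 3 (0.52 log units; beyond the scatter) shows. Compound 4 `COc1ccc(/C=C2\CN(Cc3cn(Cc4ccccc4F)nn3)C/C(=C\c3ccc(OC)cc3)C2=O)cc1` has not yet been measured. It differs from compound 3 by fluoro in place of chloro on an aromatic carbon ortho to a large group (fluoro in place of chloro on an aromatic carbon). For the measured compounds named here, no measured step makes this exact exchange. The closest evidence is a 3.9-fold higher number from compound 1 to compound 2 (0.59 log units; beyond the scatter) together with a 3.3-fold lower number from compound 2 to compound 3 (0.52 log units; beyond the scatter), but each of these changes the halogen and its place together. Going by the values given here, compound 2, the only measured fluoro compound, gives 59400 nM and has the highest number of the three. Among the compounds with values here, a shift toward a higher number in this assay is therefore expected, probably no larger than those steps. The expected step, an estimate only, is a 1.7-fold higher number from compound 3 to compound 4 (0.23 log units; within the scatter) in size. For compound 4 the estimate is 30000 nM with an expected range from 13000 nM to 70000 nM overall.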

Compound 4, half-maximal inhibitory concentration: 32600 nM
The estimate for compound 4 lay 1.1-fold (0.04 log units) below the measured number; the range from low to high includes it.
By their numbers in this assay, from the lowest: compounds 1, 3, 4 and 2 (each within the scatter of the next, the first and the last beyond it).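

In this assay, fluoro in place of chloro on an aromatic carbon ortho to a large group, seen here as a single exchange, gives a 1.8-fold higher number from compound 3 to compound 4 (0.26 log units; within the scatter) and so does not separate the two halogens at this place. With the halogen held as fluoro, 2-fluorophenyl in place of 4-fluorophenyl gives a 1.8-fold lower number from compound 2 to compound 4 (0.26 log units; within the scatter) and is also not separable, while 2-fluorophenyl in place of 3-chlorophenyl gives a 2.1-fold higher number from compound 1 to compound 4 (0.33 log units; beyond the scatter) as a modest step that changes halogen and place together. No measurement is at hand that would explain these steps.

The compounds shown leave open whether fluoro and chloro would also stay within the scatter of each other elsewhere on this ring, as a 3-fluorophenyl or 4-chlorophenyl pairing would show. They also leave open what an amine or a carboxylic acid would do at this ortho place.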